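Swapping Trifluoromethyl for Phenoxy on a Pyrrolidine Sulfonamide

A few compounds are considered here, and "the series" means these few. Any claim that something is new, unique, unknown or untested is made for them only; others in the source may bear on it.

Three compounds share a core built around a small saturated nitrogen ring with a benzyl-type arm. Compound 1 `CCOC(=O)N(Cc1ccccc1Oc1ccccc1)[C@H]1CCNC1` carries a phenoxy group on its aromatic ring, and in an assay on HEK293 cells for inhibition of sodium-dependent dopamine transporter (Homo sapiens) (on this read-out lower numbers stand for stronger inhibition and higher numbers for weaker inhibition), compound 1 gives 1900 nM. Compound 2 `CS(=O)(=O)N(Cc1ccccc1C(F)(F)F)[C@H]1CCNC1` carries trifluoromethyl in that position instead, and in this assay compound 2 gives 2890 nM. Among the two numbers available, compound 2 stands highest, yet the gap to compound 1 lies within the usual scatter, so the two compounds cannot be told apart on this read-out. Compound 3 `CC(C)C(=O)N(Cc1ccccc1C(F)(F)F)[C@H]1CCNC1`, a close relative with a different group on the nitrogen, has no result reported: in this assay compound 3 is given as "not determined" (no result reported).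

Compound 4 `CS(=O)(=O)N(Cc1ccccc1Oc1ccccc1)[C@H]1CCNC1` is the compound still to be measured. It differs from compound 2 in one place: phenoxy in place of trifluoromethyl on an aromatic carbon. Among the compounds with values here, no pair of measured compounds isolates this single change, so there is no direct precedent to lean on. Given that compound 1 and compound 2, which differ in both positions, sit within the scatter of each other, the step from compound 2 to compound 4 is expected to be small, a 1.3-fold lower number from compound 2 to compound 4 (0.12 log units; within the scatter), with no clear direction beyond the scatter. Compound 4 is therefore estimated at 2200 nM, within a range from 700 nM to 7000 nM.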

Compound 4, inhibition constant: 2550 nM
Beside the measured number, compound 4's estimate is 1.2-fold (0.06 log units) below it; the range from low to high includes it.
By their numbers in this assay, from the lowest: compounds 1, 4 and 2 (each within the scatter of the next).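

In this assay, replacing trifluoromethyl with phenoxy on this aromatic carbon while methylsulfonyl stays on the amine nitrogen gives a small step (a 1.1-fold lower number from compound 2 to compound 4 (0.05 log units; within the scatter)), so going from 4 heavy atoms to 7 and adding a six-membered aromatic ring produces no difference that can be told from the scatter. Within the data shown here, the other single change, methylsulfonyl in place of ethoxycarbonyl on the amine nitrogen with phenoxy kept, is just as unresolved (a 1.3-fold higher number from compound 1 to compound 4 (0.13 log units; within the scatter)), and together these two steps show each place changed on its own for the first time, where compounds 1 and 2 differed in both at once. Nothing shown here gives a measured reason for either result.

The compounds shown leave open whether an amine or a carboxylic acid on the aromatic ring, in place of phenoxy or trifluoromethyl, would shift the number beyond the scatter. From the compounds shown here alone, it is equally open whether a longer chain on the amine nitrogen would do so, since compound 3, the only other variation at that nitrogen, has no number to compare.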